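This account rests on a few compounds, and the source may have more. Where it says the series, first, only, none or still open, it means among the compounds named here.

In a functional assay on Caco-2 cells (Homo sapiens) for antiproliferative activity, read by MTT assay (on this read-out lower numbers stand for stronger inhibition and higher numbers for weaker inhibition), compound 1 `NS(=O)(=O)c1cccc(/N=C2\NC(=O)/C(=C3/C(=O)Nc4ccccc43)S2)c1` gives 12100 nM. Compound 2 `NS(=O)(=O)c1cccc(/N=C2\NC(=O)/C(=C3/C(=O)Nc4ccc(Cl)cc43)S2)c1` carries a chloro in place of hydrogen on an aromatic carbon of the shared core; in this assay compound 2 gives 5870 nM, and a 2.1-fold lower number from compound 1 to compound 2 (0.31 log units; beyond the scatter). Compound 3 `NS(=O)(=O)c1cccc(/N=C2\NC(=O)/C(=C3/C(=O)Nc4ccc([N+](=O)[O-])cc43)S2)c1` instead carries a nitro in place of hydrogen on an aromatic carbon; in this assay compound 3 gives 20600 nM, the highest of the three numbers, with a 1.7-fold higher number from compound 1 to compound 3 (0.23 log units; within the scatter) and a 3.5-fold higher number from compound 2 to compound 3 (0.55 log units; beyond the scatter). Compound 4 `COc1ccc2c(c1)/C(=C1/S/C(=N/c3cccc(S(N)(=O)=O)c3)NC1=O)C(=O)N2` differs from compound 3 in one place: methoxy in place of nitro on an aromatic carbon. Among the compounds with values here, no measured step involves a methoxy, so the only guides are the step that introduced the nitro, a 1.7-fold higher number from compound 1 to compound 3 (0.23 log units; within the scatter), and the step that exchanged chloro for nitro, a 3.5-fold higher number from compound 2 to compound 3 (0.55 log units; beyond the scatter). Taking the nitro away is expected to bring the number back toward where compound 1 stands, while the methoxy itself has no precedent among the measured compounds. The step is therefore expected to be a modest lowering in this assay, a 2.1-fold lower number from compound 3 to compound 4 (0.31 log units; beyond the scatter). For compound 4 the estimate in this assay is 10000 nM, with a range from 4000 nM to 25000 nM.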

Compound 4, half-maximal inhibitory concentration: 8390 nM
For compound 4 the middle estimate is 1.2-fold (0.08 log units) above the measured one; measured number inside the range.
By their numbers in this assay, from the lowest: compounds 2, 4, 1 and 3 (each within the scatter of the next, the first and the last beyond it).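

In this assay, this aromatic carbon now shows a readable exchange between two substituents that carry oxygen, with a 2.5-fold lower number from compound 3 to compound 4 (0.39 log units; beyond the scatter) for methoxy in place of nitro. Methoxy cannot be separated from either of the other two groups at this position, since a 1.4-fold higher number from compound 2 to compound 4 (0.16 log units; within the scatter) and a 1.4-fold lower number from compound 1 to compound 4 (0.16 log units; within the scatter) both leave compound 4 within the scatter, even though compound 1 and compound 2 are themselves just beyond it; compound 4 therefore fits with both, and the data draw no order among them. Nothing measured here explains why the exchange of nitro for methoxy gives this step, and a count of atoms or hydrogen-bond acceptors does not supply a reason.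

On these data alone, whether an amine, a carboxylic acid or a longer chain such as ethoxy on this same carbon would stay close to these numbers or move well away from them remains open. Also open, as far as these compounds go, is whether methoxy in place of nitro would give a step of similar size if the sulfonamide-bearing ring of the shared core were changed.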